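This account rests on a few compounds, and the source may have more. Where it says the series, first, only, none or still open, it means among the compounds named here.

Compound 1 `O=C(O)Cc1sc(C(c2ccccc2)c2ccc(Cl)cc2)nc1-c1ccc(Cl)cc1` gives 80% in an in vitro functional assay on HEK285-7 cells for antagonist activity at prostaglandin D2 receptor 2 (Homo sapiens), read by BRET and beta-arrestin recruitment; a higher number here means a larger maximal response, a lower number a smaller maximal response. Compound 2 `O=C(O)Cc1sc(C(c2ccc(F)cc2)c2ccc(F)cc2)nc1-c1ccc(Cl)cc1` gives 80% in this assay, level with compound 1 at the digits shown; the two values lie within the scatter of each other, so no order between them can be drawn. Compound 3 `N#Cc1cc(-c2nc(C(c3ccc(F)cc3)c3ccc(F)cc3)sc2CC(=O)O)ccc1F` is not yet measured. It differs from compound 2 as follows: 3-cyano-4-fluorophenyl in place of 4-chlorophenyl on an aromatic carbon. Among the measured compounds shown here, no step between measured compounds touches this position, so the data give no direct guide to the size of its effect. The two measured compounds sit at one level, which leaves only a small step to be expected here. Compound 3 is expected to give about 80% in this assay, with a range from 65% to 92%. The step this expectation means, no change at the digits printed from compound 2 to compound 3 (within the scatter), is estimated to stay within the scatter rather than beyond it.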

Compound 3, largest response reached (reported as efficacy), in percent of the reference or control that the assay uses: 80%
Estimate against measurement, compound 3: no gap at the digits printed, within the range that was stated.
By their numbers in this assay, from the lowest: compounds 1, 2 and 3 (each within the scatter of the next).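

In this assay the aromatic carbon next to the ring nitrogen now has its first reading, with no change at the digits printed from compound 2 to compound 3 (within the scatter) on replacing 4-chlorophenyl by 3-cyano-4-fluorophenyl. At this position, then, the maximal response does not separate the chlorine-bearing aryl group from the one bearing a nitrile and a fluorine, although the entering group has more heavy atoms. No accompanying measurement bears on this result.

As far as these compounds go, whether an amine or a carboxylic acid on this aryl ring, or a simple alkyl chain in its place, would move the maximal response stays open. Among the compounds shown here, only one step at this position is in hand, so how far the response can shift here also remains unknown.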